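This account rests on a few compounds, and the source may have more. Where it says the series, first, only, none or still open, it means among the compounds named here.

Compound 1 `CC1CCN(Cc2ccc3nc(NC(=O)N/N=C/c4cn(Cc5ccc(Cl)cc5Cl)c5ccccc45)sc3c2)CC1`: 3140 nM
Compound 2 `CCN(CC)Cc1ccc2nc(NC(=O)N/N=C/c3cn(Cc4ccc(Cl)cc4Cl)c4ccccc34)sc2c1`: 3280 nM

In a functional assay on MDA-MB-231 cells (Homo sapiens) for cytotoxicity, read by MTT assay, with a stated time of 72 h (on this read-out lower numbers stand for stronger inhibition and higher numbers for weaker inhibition), compound 2 gives 3280 nM, level with compound 1 within the scatter. Among the compounds with values here, the only measured step, a 1.0-fold higher number from compound 1 to compound 2 (0.02 log units; within the scatter), exchanges 4-methylpiperidin-1-yl for diethylamino and leaves the benzyl group untouched. Compound 3 `CCN(CC)Cc1ccc2nc(NC(=O)N/N=C/c3cn(Cc4ccc(Cl)cc4)c4ccccc34)sc2c1` keeps the diethylamino group of compound 2 but has 4-chlorobenzyl in place of 2,4-dichlorobenzyl: hydrogen in place of chloro on an aromatic carbon. Within the data shown here, no measured step covers this change, so the data give no direction for it, and no shift beyond the scatter is expected. The expected step is a 1.1-fold higher number from compound 2 to compound 3 (0.03 log units; within the scatter). Compound 3 is estimated at 3500 nM, with a range from 1300 nM to 9500 nM.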

Compound 3, half-maximal inhibitory concentration: 2570 nM
For compound 3 the middle estimate is 1.4-fold (0.13 log units) above the measured one, within the range that was stated.
By their numbers in this assay, from the lowest: compounds 3, 1 and 2 (each within the scatter of the next).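

In this assay, within the data shown here, putting hydrogen in place of chloro on this aromatic carbon gives a 1.3-fold lower number from compound 2 to compound 3 (0.11 log units; within the scatter) and so brings the first measurement at this position. The earlier step changed only the amine and left the benzyl group untouched, whereas this one shows that 2,4-dichlorobenzyl and 4-chlorobenzyl read alike here. No measurement shown here accounts for this result. Going by these compounds, whether fluoro, methoxy or trifluoromethyl at this position would read the same stays open. So does the effect of losing the remaining chloro group, which would leave an unsubstituted benzyl group.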